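The source may report more compounds than this note shows. Statements on the series, on what has been measured and on what is new or still open speak of the compounds shown alone.

Compound 1 `CCCNC(=O)CC1CCc2cc(OC)c(OC)cc21` in a functional assay on the whole organism (strain Wistar) for inhibition, with Rattus norvegicus as the target, read by paw edema, with stated times of 60 min and 4 h, at a dose of 100 mg/kg by the oral route (on this read-out lower numbers stand for less inhibition and higher numbers for more inhibition at the one dose given (going by the name of the read-out)), gives 26.6%.
Compound 2 `COc1cc2c(cc1OC)C(CC(=O)NC1CCCC1)CC2` in this assay gives 45.3%.
Compound 3 `COc1cc2c(cc1OC)C(CC(=O)NCc1ccccc1)CC2` in this assay gives 18.8%.

Compound 3 has the lowest of the three numbers. Its nearest neighbour is compound 1, and that gap, a number 7.8 percentage points lower from compound 1 to compound 3 (within the scatter), lies within the scatter; the gap to compound 2, a number 26.5 percentage points lower from compound 2 to compound 3 (beyond the scatter), lies beyond it. Compound 4 `COc1cc2c(cc1OC)C(CC(=O)N1CCCC1)CC2` differs from compound 3 in one place: pyrrolidin-1-yl in place of benzylamino on a carbonyl carbon. For the measured compounds named here, no measured step makes exactly this exchange, so none bears on it directly. The closest guides are the exchange of benzyl for cyclopentyl on the amide-type nitrogen, where the number moved a number 26.5 percentage points lower from compound 2 to compound 3 (beyond the scatter) in the opposite direction, and the move from propyl to cyclopentyl, a number 18.7 percentage points higher from compound 1 to compound 2 (beyond the scatter). Both favour a saturated ring over an open chain or a benzyl group, but neither changes the count of hydrogen-bond donors, as the present exchange does. Compound 4 is therefore expected to show a step of about a number 11.2 percentage points higher from compound 3 to compound 4 (beyond the scatter), with considerable uncertainty. Compound 4 is estimated in this assay at 30%, within a range from 12% to 48%.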

Compound 4, a percentage reported as inhibition, in the whole organism at one dose (the size of the read-out at that dose, not a potency): 24.2%
Compound 4: middle estimate off by 5.8 percentage points, on the high side, and the stated range covers the measured number.
By their numbers in this assay, from the lowest: compounds 3, 4 and 1 (each within the scatter of the next); then compound 2.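

In this assay, the exchange on a carbonyl carbon that removes the hydrogen-bond donor of benzylamino stays within the scatter, a number 5.4 percentage points higher from compound 3 to compound 4 (within the scatter), and pyrrolidin-1-yl in place of propylamino does too, a number 2.4 percentage points lower from compound 1 to compound 4 (within the scatter). A saturated ring on this carbon therefore does not by itself bring the higher number of compound 2, since pyrrolidin-1-yl in place of cyclopentylamino gives a number 21.1 percentage points lower from compound 2 to compound 4 (beyond the scatter), which sets cyclopentylamino apart from the other three groups. Nothing at hand gives a reason for these steps.

The compounds shown leave open whether another ring on a nitrogen that keeps its hydrogen, such as cyclohexylamino, would come close to compound 2, and whether piperidin-1-yl would stay with compound 4. Going by these compounds, each number comes from one dose, so how these groups compare in potency also stays open.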